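Chloro to Nitro on the Side Ring: Weak Inhibitor Expected

The source may report more compounds than this note shows. Statements on the series, on what has been measured and on what is new or still open speak of the compounds shown alone.

Three compounds share one core. Compound 1 `C#CCOc1ccc2oc(=O)ccc2c1` has as its result in a functional assay on HL-60 cells (Homo sapiens) for cytotoxicity, read by MTT assay, with a stated time of 48 h (a lower number here means a stronger inhibitor, a higher number a weaker inhibitor), only "not determined" (no result reported), so it offers nothing to compare. Within the data shown here, compound 2 `O=c1ccc2cc(OCc3cc(-c4cccc(Cl)c4)no3)ccc2o1` is therefore the single reference point: in this assay compound 2 gives 50600 nM, the only number in the set, and a large one, meaning a weak inhibitor. Compound 3 `O=c1ccc2cc(OCc3cc(-c4cccc([N+](=O)[O-])c4)no3)ccc2o1` differs from compound 2 in one place: nitro in place of chloro on an aromatic carbon. Among the measured compounds shown here, no step between two measured compounds is known, so there is no guide from the data to how this exchange shifts the number. With nothing pointing one way or the other, the step from compound 2 to compound 3 is expected to stay within the usual scatter, as a 1.1-fold lower number from compound 2 to compound 3 (0.05 log units; within the scatter). Compound 3 is accordingly estimated at 45000 nM in this assay, with a range from 15000 nM to 150000 nM.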

Compound 3, half-maximal inhibitory concentration: 44400 nM
The estimate for compound 3 lay 1.0-fold (0.01 log units) above the measured number; the measured number falls inside the stated range.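

Among these compounds, the exchange of 3-chlorophenyl for 3-nitrophenyl gives the first step that can be read in this set: a 1.1-fold lower number from compound 2 to compound 3 (0.06 log units; within the scatter) in this assay. At this place on the side ring, then, chloro and nitro cannot be told apart in this assay, even though nitro has more heavy atoms and carries hydrogen-bond acceptors, which chloro does not. No independent measurement is available to explain this result.

From the compounds shown here alone, both compounds are weak inhibitors, so it remains open whether an amine, a carboxylic acid or a methoxy group at this place would give a clearly different number. Going by these compounds, this is also a single pair, and whether the same exchange would give so small a step on a different core remains open.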